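Working notes: trifluoromethyl in place of chloro

A few compounds are considered here, and "the series" means these few. Any claim that something is new, unique, unknown or untested is made for them only; others in the source may bear on it.

compound 1 `CCCCCC1(O)C(=O)Nc2ccc(Nc3ccc(C)cc3)cc21`: 8100 nM
compound 2 `CCCCCC1(O)C(=O)Nc2ccc(Nc3ccc(Cl)cc3)cc21`: 1900 nM

Within the data shown here, in a functional assay on A549 cells (Homo sapiens) for antiproliferative activity, read by MTT assay, with a stated time of 48 h (on this read-out higher numbers stand for weaker inhibition and lower numbers for stronger inhibition), compound 2 gives 1900 nM, the lower of the two numbers so far. Compound 3 `CCCCCC1(O)C(=O)Nc2ccc(Nc3ccc(C(F)(F)F)cc3)cc21` keeps the shared core and carries trifluoromethyl in place of chloro on an aromatic carbon. Among the measured compounds shown here, one measured step bears on this change: a 4.3-fold lower number from compound 1 to compound 2 (0.63 log units; beyond the scatter). It is modest, lies beyond the scatter and comes from chloro in place of methyl on an aromatic carbon. For the measured compounds named here, two compounds set no trend, and no measurement yet compares trifluoromethyl with either group. From the compounds shown here alone, a step beyond the scatter is therefore not expected in this assay, and the direction stays open, with a slight lean to a higher number. The expected size is a 1.3-fold higher number from compound 2 to compound 3 (0.10 log units; within the scatter). Compound 3 is estimated at 2400 nM, with an expected range of 950 nM to 6000 nM.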

Compound 3, half-maximal inhibitory concentration: 2200 nM
For compound 3 the middle estimate is 1.1-fold (0.04 log units) above the measured one; measured number inside the range.
By their numbers in this assay, from the lowest: compounds 2 and 3 (each within the scatter of the next); then compound 1.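

In this assay, on this aromatic carbon para to a large group, a 1.2-fold higher number from compound 2 to compound 3 (0.06 log units; within the scatter) shows that trifluoromethyl, with 4 heavy atoms, and chloro, with 1 heavy atom, cannot be separated by this read-out. Methyl now differs from two groups rather than one: a 3.7-fold lower number from compound 1 to compound 3 (0.57 log units; beyond the scatter) is modest and lies beyond the scatter, so the gain seen with chloro is not confined to chloro. Nothing available gives a reason for these differences.

From the compounds shown here alone, whether a group of another kind on this carbon, such as an amine, a carboxylic acid or a methoxy group, stays within the scatter of chloro remains open. Also open, going by these compounds, is whether the same steps hold with a shorter chain on the shared core.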